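Thiazolyl for trifluoromethyl: cytotoxicity outlook for compound 4

A few compounds are considered here, and "the series" means these few. Any claim that something is new, unique, unknown or untested is made for them only; others in the source may bear on it.

Among the compounds with values here, compound 1 `O=C1CC(C(F)(F)F)CN1c1cnn2c1CN(C(=O)Nc1cc(F)c(F)c(F)c1)C(C1CC1)C2` is the one member of this set with an actual number in a toxicity assay on HepG2 2.2.15 cells (Homo sapiens) for cytotoxicity, read by CellTiter-Glo; on this read-out higher numbers stand for lower toxicity in this test and lower numbers for higher toxicity in this test: compound 1 gives 115000 nM. Compound 2 `C[C@H]1Cn2ncc(N3CC(c4ccccc4)CC3=O)c2CN1CC(=O)Nc1cc(F)c(F)c(F)c1` reaches only a limit in this assay, > 2000 nM. Compound 3 `C[C@H]1Cn2ncc(N3CC(c4ccccc4)CC3=O)c2CN1C(=O)NCc1cc(F)c(F)c(F)c1` likewise reaches only a limit in this assay, > 2000 nM. Within the data shown here, two of the three values therefore sit at the limit of > 2000 nM in this assay, at which 2 of the 3 values shown sit, so no step between measured compounds can be read, and compound 1 stands alone as the reference.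

Compound 4 `O=C1CC(c2nccs2)CN1c1cnn2c1CN(C(=O)Nc1cc(F)c(F)c(F)c1)C(C1CC1)C2` is not yet measured. Its change from compound 1: 1,3-thiazol-2-yl in place of trifluoromethyl on a saturated ring carbon. Without any measured step to lean on, the expectation for compound 4 in this assay is a shift within the scatter only, none beyond it. Compound 4 is estimated at 100000 nM, from 40000 nM to 200000 nM. The step of a 1.2-fold lower number from compound 1 to compound 4 (0.06 log units; within the scatter) is thus expected to stay small.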

Compound 4, half-maximal cytotoxic concentration: 115000 nM
Estimate against measurement, compound 4: 1.2-fold (0.06 log units) below; the measured number falls inside the stated range.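

Within the data shown here, at the saturated ring carbon of the core of compound 1, 1,3-thiazol-2-yl in place of trifluoromethyl gives the first readable step in this assay: no change at the digits printed from compound 1 to compound 4 (within the scatter). This position thus carries either a small group with no ring or a five-membered aromatic ring with 2 hetero atoms, with no step beyond the scatter. On these data alone, whether an amine or a carboxylic acid on this carbon would read the same stays open. Compounds 2 and 3 each give only a limit, not a number, so steps to them cannot be read: the limit of > 2000 nM in this assay, at which 2 of the 4 values shown sit.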